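A Methyl Added to the Core of Compound 1

This account rests on a few compounds, and the source may have more. Where it says the series, first, only, none or still open, it means among the compounds named here.

Compound 1 `C=CC[C@@H](OC(=O)C=C)c1cccc2ccccc12`: 22900 nM
Compound 2 `C=CC[C@@H](OC(=O)C=C)c1c(C)ccc2ccccc12`: 8800 nM

Going by the values given here, in a functional assay on PC-3 cells (Homo sapiens) for cytotoxicity, read by MTT assay, with a stated time of 48 h (a lower number here means a stronger inhibitor, a higher number a weaker inhibitor), compound 1 gives 22900 nM, the higher of the only two numbers measured so far, so it is the weaker inhibitor of the pair. Compound 3 `C=CC[C@@H](OC(=O)C=C)c1ccc(C)c2ccccc12` has not yet been measured. It differs from compound 1 by a methyl in place of hydrogen on an aromatic carbon, para to a group of 9 heavy atoms: methyl in place of hydrogen on an aromatic carbon.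

Among the compounds with values here, one measured step bears on this change: a 2.6-fold lower number from compound 1 to compound 2 (0.42 log units; beyond the scatter). That step is the same exchange of hydrogen for methyl, made on a different aromatic carbon, and it is modest but beyond the scatter. A single step is thin evidence, and the data do not show how much the place of the methyl matters. A modest move toward a lower number in this assay is therefore expected, although a change within the scatter remains possible. The expected step is a 1.9-fold lower number from compound 1 to compound 3 (0.28 log units; within the scatter). For compound 3 the estimated value is 12000 nM, with an expected range of 5500 nM to 25000 nM.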

Compound 3, half-maximal inhibitory concentration: 45000 nM
Compound 3: the middle estimate sits 3.8-fold (0.57 log units) below what was measured; measured number outside the range, above it.
By their numbers in this assay, from the lowest: compound 2; then compounds 1 and 3 (each within the scatter of the next).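

In this assay, placing the methyl on the aromatic carbon para to a group of 9 heavy atoms gives a 2.0-fold higher number from compound 1 to compound 3 (0.29 log units; within the scatter), so at this position the exchange leaves the number within the scatter of compound 1. The same exchange on a different aromatic carbon gave a 2.6-fold lower number from compound 1 to compound 2 (0.42 log units; beyond the scatter), which shows that the lower number seen with compound 2 does not extend to every aromatic carbon of the core, and that the place of the methyl counts across these two steps. Nothing at hand accounts for the difference between the two carbons.

The compounds shown leave open whether another group on this carbon, such as a methoxy group, a chlorine atom or an amine, would move the number clearly away from that of compound 1. Going by these compounds alone, they also leave open whether a methyl on the remaining aromatic carbons of the core would behave like the one in compound 2 or the one in compound 3, and what a longer chain would do in its place.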